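A few compounds are considered here, and "the series" means these few. Any claim that something is new, unique, unknown or untested is made for them only; others in the source may bear on it.

For the measured compounds named here, compound 3 `COc1cc(Cl)cc(-c2nn(-c3cccc(NC(=O)Nc4ccc(Cl)c(C(F)(F)F)c4)c3)cc2-c2ccncc2)c1` gives -71.2% in a functional assay on SK-MEL-5 cells (Homo sapiens) for inhibition, read by sulforhodamine B assay, with a stated time of 48 h, tested at 10 uM (a higher number here means a weaker effect of the compound at the concentration tested, a lower number a stronger effect), the lowest of the three numbers measured so far, and thus the strongest effect at the concentration tested. Its nearest neighbour is compound 2 `O=C(Nc1cccc(-n2cc(-c3ccncc3)c(-c3cc(O)cc(Cl)c3)n2)c1)Nc1ccc(Cl)c(Cl)c1`, which gives -53.1% in this assay; the furthest is compound 1 `COc1cc(Cl)cc(-c2nn(-c3cccc(NC(=O)c4ccc(Cl)c(Cl)c4)c3)cc2-c2ccncc2)c1`, which gives 78.5% in this assay. Going by the values given here, the one measured step that runs from compound 1 to compound 3 is a number 149.7 percentage points lower from compound 1 to compound 3 (beyond the scatter), but it swaps two things at once, the amide for a urea and the 3,4-dichlorophenyl for the (4-chloro-3-(trifluoromethyl)phenyl)amino, so it does not isolate the change now at hand.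

Compound 4 `COc1cc(Cl)cc(-c2nn(-c3cccc(NC(=O)Nc4ccc(Cl)c(Cl)c4)c3)cc2-c2ccncc2)c1` keeps the urea of compound 3 and differs only in the end group: chloro in place of trifluoromethyl on an aromatic carbon. Compound 2 carries the same (3,4-dichlorophenyl)amino on its carbonyl carbon and sits close to compound 3 in this assay, which hints that this swap matters little. The step from compound 3 to compound 4 in this assay is therefore expected to be small, a number 11.2 percentage points higher from compound 3 to compound 4 (beyond the scatter), a slight weakening that may fall within the scatter. Compound 4 is estimated to give -60% in this assay, within a range of -95% to -20%.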

Compound 4, a percentage reported as activity, at one concentration (the size of the read-out at that concentration, not a potency): 3.51%
Estimate against measurement, compound 4: 63.5 percentage points below; measured number above the stated range.
By their numbers in this assay, from the lowest: compound 3; then compound 2; then compound 4; then compound 1.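

The trifluoromethyl position, ortho to a chloro group, is far from neutral on the urea series: in this assay, the swap to chloro gives a number 74.7 percentage points higher from compound 3 to compound 4 (beyond the scatter) and moves the compound to a clearly weaker effect at the concentration tested. With the (3,4-dichlorophenyl)amino group held constant, placing a methyl in place of hydrogen on the oxygen of the aromatic ring gives a number 56.6 percentage points higher from compound 2 to compound 4 (beyond the scatter) and also weakens the effect, so this second site matters as well. For the compounds shown here, the new compound also gives the first clean reading of the linker. Only the (3,4-dichlorophenyl)amino group replacing 3,4-dichlorophenyl on the carbonyl carbon separates the two compounds in a number 75 percentage points lower from compound 1 to compound 4 (beyond the scatter), a change toward a stronger effect.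

No measured information here explains why any of these steps is so large. Still open, going by these compounds, is how a methyl or a nitrile at the trifluoromethyl position would compare, and whether the chloro and trifluoromethyl swap would give a step of similar size on the amide of compound 1 or with the hydroxyl of compound 2.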